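Compound 3: a new group where a large step was seen

The compounds below may be only part of what the source reports. "The series", "measured", "known", "first", "only" and "open" are said of these compounds alone.

compound 1 `Cc1nc(C)c([C@H](OC(C)(C)C)C(=O)O)c(N2CCC(C)(C)CC2)c1-c1ccc2c(c1)CCN(Cc1cccc(F)c1F)C2`: 50%
compound 2 `Cc1nc(C)c([C@H](OC(C)(C)C)C(=O)O)c(N2CCC(C)(C)CC2)c1-c1ccc2c(c1)CCN(c1ncnc3c1cnn3C)C2`: 95%

Both values come from an ADME assay on the whole organism (Rattus norvegicus, strain Sprague-Dawley) for pharmacokinetics, read by LC-MS, at a dose of 5 mg/kg by the oral route; on this read-out lower numbers stand for lower oral bioavailability and higher numbers for higher oral bioavailability. Compound 2 stands higher of the two, beyond the scatter. Compound 3 `Cc1nc(C)c([C@H](OC(C)(C)C)C(=O)O)c(N2CCC(C)(C)CC2)c1-c1ccc2c(c1)CCN(c1nccc(-c3cnccn3)n1)C2` has not been measured yet and differs from compound 2 as follows: a group of 12 heavy atoms (8 carbon, 4 nitrogen; 2 six-membered aromatic rings with 2 hetero atoms each) in place of a group of 10 heavy atoms (6 carbon, 4 nitrogen; one five-membered aromatic ring with 2 hetero atoms, one six-membered aromatic ring with 2 hetero atoms), on an amine nitrogen in a ring. Going by the values given here, only one measured step bears on this amine nitrogen in a ring: a number 45 percentage points higher from compound 1 to compound 2 (beyond the scatter). That large step involved different groups, so it shows sensitivity here but not the size of this change. A drop is expected because compound 2 gives 95% and has little room to rise. The expected step is a number 25 percentage points lower from compound 2 to compound 3 (beyond the scatter). For compound 3, the estimate is 70%, with a range of 40% to 95%.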

Compound 3, oral bioavailability: 38%
Beside the measured number, compound 3's estimate is 32 percentage points above it; the whole stated range lies above it.
By their numbers in this assay, from the lowest: compound 3; then compound 1; then compound 2.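

At this amine nitrogen in a ring, this assay gives a number 57 percentage points lower from compound 2 to compound 3 (beyond the scatter), although the entering and leaving groups both hold 4 nitrogen atoms and 4 hydrogen-bond acceptors. There is also a number 12 percentage points lower from compound 1 to compound 3 (beyond the scatter), so compound 2 and compound 3 lie on opposite sides of compound 1 and nitrogen count alone does not set the direction of the change. No measurement shown gives a cause for this drop. Still open, as far as these compounds go, is how a single aromatic ring, such as pyrimidine, or a small group, such as acetyl, would read at this nitrogen.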